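The source may report more compounds than this note shows. Statements on the series, on what has been measured and on what is new or still open speak of the compounds shown alone.

Among the measured compounds shown here, compound 1, `Fc1ccc(-c2nc3cc(C(F)(F)F)ccc3[nH]2)cc1`, is the only compound among the two measured in an ADME assay on Vero cells (Chlorocebus sabaeus) for cytotoxicity (on this read-out higher numbers stand for lower toxicity in this test and lower numbers for higher toxicity in this test), that yields a number rather than a limit. In this assay compound 1 gives 60000 nM. Compound 2, `CC(=O)Nc1ccc(-c2nc3ccccc3[nH]2)cc1`, in this assay reaches only a limit of the assay, > 100000 nM. For the measured compounds named here, compound 2 is thus the one value that sits at the limit of > 100000 nM in this assay, at which 1 of the 2 values shown sits. Compound 2 stops at a limit. Going by the values given here, the two values shown therefore cannot be set against each other as a step; they show only that compound 1 has a number and compound 2 does not.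

Compound 3, `Oc1ccc(-c2nc3cc(C(F)(F)F)ccc3[nH]2)cc1`, differs from compound 1 by hydroxy in place of fluoro on an aromatic carbon. Among the compounds with values here, no measured step of this kind is available here, so the expectation rests on the change itself and on where compound 1 stands. In this assay a small step is expected, toward lower toxicity if any, and one that may well stay within the usual scatter. The step from compound 1 to compound 3 is thus expected to be a 1.3-fold higher number from compound 1 to compound 3 (0.12 log units; within the scatter). Compound 3 is estimated to give 80000 nM in this assay, with a range from 35000 nM to 200000 nM.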

Compound 3, half-maximal cytotoxic concentration: > 100000 nM
Compound 3: a limit, no number (the forecaster's own chance of this, stated with the estimate: 35%); middle value at least 1.2-fold (0.09 log units) away from the limit.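

Hydroxy in place of fluoro on an aromatic carbon, para to a large group, gives the first step that can be read in this assay, an at least 1.6-fold higher number from compound 1 to compound 3 (0.22 log units; that floor lies within the scatter). Going by these compounds, for compound 3 the value > 100000 nM is a limit of the assay and not a number, so only the floor of this step is fixed and its true size stays unknown. The change thus shows what the earlier compounds could not: with the rest of the core of compound 1 held constant, this position takes hydroxy without any sign of a lower number, yet the scale can show little more here because of where the values now sit: the limit of > 100000 nM in this assay, at which 2 of the 3 values shown sit.

On these data alone, what stays open is whether an amine, a methoxy group or a carboxylic acid at this same position would also end at the limit or would give a number that could be set against compound 1. Equally open, as far as these compounds go, is whether the hydroxy step would read the same with a chlorine or a nitrile in place of the trifluoromethyl group on the shared core.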